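Butyl to cyclopentyl on the amine of a triazolotriazine core

The compounds below may be only part of what the source reports. "The series", "measured", "known", "first", "only" and "open" are said of these compounds alone.

Measured compounds:
compound 1 `CCCCCC(=O)N1CCN(c2nnc3nncn3n2)CC1` gives 5260 nM
compound 2 `CCCCNc1nnc2nncn2n1` gives 13700 nM
compound 3 `CC(=O)N1CCN(c2nnc3nncn3n2)CC1` gives 13900 nM

All three were read in a functional assay on MCF7 cells (Homo sapiens) for inhibition, read by MTT assay, with a stated time of 72 h; on this read-out higher numbers stand for weaker inhibition and lower numbers for stronger inhibition. Compound 2 sits with compound 3: the gap between them is within the scatter, so nothing separates the two. Among the measured compounds shown here, compound 1 is the only compound that stands apart from compound 2, its number being lower beyond the scatter.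

Compound 4 `c1nnc2nnc(NC3CCCC3)nn12` is not yet measured. It differs from compound 2 in one place: cyclopentyl in place of butyl on a nitrogen on an aromatic ring

For the measured compounds named here, no measured pair exchanges one hydrocarbon group for another on this nitrogen. Going by the values given here, the single step that touches a butyl group is a 2.6-fold higher number from compound 1 to compound 3 (0.42 log units; beyond the scatter), and that change removes the chain altogether rather than replacing it, on a saturated chain carbon bound to a carbonyl carbon rather than on the ring nitrogen. Going by these compounds, it shows that shortening a chain at a different place costs a modest amount, so a chain of similar size should not lose ground; whether a ring gains is untested here.

For compound 4 the estimate is a step of about a 1.4-fold lower number from compound 2 to compound 4 (0.14 log units; within the scatter) in this assay, within or near the scatter. Compound 4 is therefore expected at 10000 nM, with a range from 4000 nM to 25000 nM.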

Compound 4, half-maximal inhibitory concentration: 88200 nM
For compound 4 the middle estimate is 8.8-fold (0.95 log units) below the measured one; measured number above the stated range.
By their numbers in this assay, from the lowest: compound 1; then compounds 2 and 3 (each within the scatter of the next); then compound 4.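

This nitrogen on an aromatic ring is the one place in the series where one hydrocarbon group is exchanged for another, and in this assay the exchange of butyl for cyclopentyl gives a 6.4-fold higher number from compound 2 to compound 4 (0.81 log units; beyond the scatter), a loss of inhibition. The two groups are close in the counted terms, with 4 heavy atoms in butyl and 5 heavy atoms in cyclopentyl, and neither has hydrogen-bond donors, hydrogen-bond acceptors or a net charge, so similar size alone does not hold the number at this position in this one pair. Nothing measured here accounts for the loss.

The compounds shown do not tell whether the loss follows from the closed ring, from branching at the carbon on the nitrogen, or from the added carbon, and a pentyl chain, an isopropyl group or a cyclohexyl ring on this nitrogen would separate these readings. Going by these compounds, it also remains open whether a group on this nitrogen exists that lowers the number relative to butyl, such as a shorter propyl chain or a benzyl group.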